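The source may report more compounds than this note shows. Statements on the series, on what has been measured and on what is new or still open speak of the compounds shown alone.

Measured compounds in a functional assay on WI-38 VA13 cells (Homo sapiens) for cytotoxicity; on this read-out higher numbers stand for an effect only at larger amounts of compound and lower numbers for an effect already at smaller amounts:
compound 1, `Cc1ccccc1C(=O)Nc1ccc2nc(NC(=O)C3CCCCC3)sc2c1`: 0.085 ug/mL
compound 2, `O=C(Nc1ccc2nc(NC(=O)C3CCCCC3)sc2c1)c1cccc(F)c1`: 0.64 ug/mL
compound 3, `CCCCCCCC(=O)Nc1nc2ccc(NC(=O)c3c(Cl)cccc3Cl)cc2s1`: 0.18 ug/mL

Compound 3 stands second highest of the three numbers. Compound 1 gives the lower number and compound 2 the higher one, and both gaps to compound 3 lie beyond the scatter. For the measured compounds named here, the only change tracked between two measured compounds is a 7.5-fold higher number from compound 1 to compound 2 (0.88 log units; beyond the scatter); it alters the group on the other carbonyl carbon of the shared core and says nothing about the nitrogen on the aromatic ring that is varied next.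

Compound 4, `CCCCCNc1nc2ccc(NC(=O)c3c(Cl)cccc3Cl)cc2s1`, is not yet measured. Relative to compound 3 the change is pentyl in place of heptylcarbonyl on a nitrogen on an aromatic ring. The carbonyl is lost and the chain is shorter. Going by the values given here, no measured pair shows this kind of change, so no step can be carried over; the step from compound 1 to compound 2 bears on it only in showing that a single change on the shared core can move this assay beyond the scatter. The direction is open, with a wide range. For compound 4 the expected value in this assay is 0.4 ug/mL, between 0.08 ug/mL and 2 ug/mL. This estimate corresponds to an expected step of a 2.2-fold higher number from compound 3 to compound 4 (0.35 log units; beyond the scatter).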

Compound 4, half-maximal effective concentration: 0.27 ug/mL
The estimate for compound 4 lay 1.5-fold (0.17 log units) above the measured number; measured number inside the range.
By their numbers in this assay, from the lowest: compound 1; then compounds 3 and 4 (each within the scatter of the next); then compound 2.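

In this assay, pentyl in place of heptylcarbonyl on a nitrogen on an aromatic ring gives a 1.5-fold higher number from compound 3 to compound 4 (0.18 log units; within the scatter) and so does not move the read-out in a way that can be distinguished from repeat measurements. For the compounds shown here, this is the first information on this position: for this pair, the carbonyl on this nitrogen is not needed to keep the number within the scatter of compound 3, even with the shorter chain. The single change on the other carbonyl carbon, by contrast, gave a 7.5-fold higher number from compound 1 to compound 2 (0.88 log units; beyond the scatter), so the sensitivity seen there does not appear in this one change at this nitrogen; no data shown account for the similar numbers of compound 3 and compound 4.

Because the carbonyl and the chain length change together, this pair cannot assign any part of the step to either one, and a heptyl chain on the same nitrogen or a hexanoyl group that keeps the carbonyl would separate the two. Also open, on these data alone, is whether this flat response holds for groups unlike simple chains at this nitrogen, such as a terminal amine or a carboxylic acid on the chain.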